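Methoxycarbonyl to carboxy on the core of compound 1

The source may report more compounds than this note shows. Statements on the series, on what has been measured and on what is new or still open speak of the compounds shown alone.

For the measured compounds named here, in a functional assay on HT-29 cells (Homo sapiens) for cytotoxicity, read by MTT assay, with a stated time of 6 days (a lower number here means that less compound is needed, a higher number that more compound is needed for the effect), compound 1 `COC(=O)c1c(-c2cc(OC)cc(OC)c2)oc2ccccc2c1=O` gives 6.99 ug/mL, the only true number so far. Compound 2 `COC(=O)c1c(-c2ccc([N+](=O)[O-])cc2)oc2cc(OC)ccc2c1=O` gives > 25 ug/mL, which is a limit and not a number. These two compounds differ in more than one place, so no single change can be read from them.

Compound 3 `COc1cc(OC)cc(-c2oc3ccccc3c(=O)c2C(=O)O)c1` departs from compound 1 in one place: hydrogen in place of methyl on an oxygen next to a carbonyl group. This puts hydrogen in place of methyl on an oxygen next to a carbonyl group, turning methoxycarbonyl into carboxy. Going by the values given here, no measured step covers this change, so the expectation is a judgement: a moderate move toward a higher number in this assay, beyond the scatter. The step expected is a 2.6-fold higher number from compound 1 to compound 3 (0.41 log units; beyond the scatter). For compound 3 the estimated value is 18 ug/mL, with an expected range of 7 ug/mL to 25 ug/mL.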

Compound 3, concentration for half-maximal effect: > 25 ug/mL
Compound 3 gave a limit, no number; the forecaster's own chance of this, stated with the estimate: 50%; middle value at least 1.3-fold (0.14 log units) from the limit.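

For the compounds shown here, on the core of compound 1, methoxycarbonyl to carboxy is the first change that can be read on its own: in this assay it gives an at least 3.5-fold higher number from compound 1 to compound 3 (0.55 log units; beyond the scatter). For compound 3 the value of > 25 ug/mL is a limit and not a number, so this step has a lower bound but no known size. Compound 1 therefore remains the only compound with a true number, and the step can be read only against the shared ceiling of the assay: the limit of > 25 ug/mL in this assay, at which 2 of the 3 values shown sit.

Left open is how far the number rises for compound 3, and whether the shift belongs to the loss of the methyl alone. An ethyl group on this oxygen, or an amide in place of the carboxy group, would show whether any replacement keeps a true number.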